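From ethyl to cyano on compound 2

The compounds below may be only part of what the source reports. "The series", "measured", "known", "first", "only" and "open" are said of these compounds alone.

Compounds measured so far in an ADME assay on liver (Homo sapiens) for metabolic stability, read by LC-MS, with a stated time of 30 min (on this read-out higher numbers stand for fast clearance and lower numbers for slow clearance), with their clearance values
- compound 1 `CCc1ccc(N(C2CCC2)S(=O)(=O)c2ccc3c(c2)C(O)CC(C2CCOCC2)O3)cc1` gives 27.1 mL/min/kg here
- compound 2 `CCc1ccc(N(CC(C)C)S(=O)(=O)c2ccc3c(c2)C(O)CC(C2CCOCC2)O3)cc1` gives 330 mL/min/kg here
- compound 3 `O=S(=O)(c1ccc2c(c1)C(O)CC(C1CCOCC1)O2)N1CCCC1c1ccccc1C(F)(F)F` gives 172 mL/min/kg here

In this assay compound 2 and compound 3 sit within the scatter of each other, both on the fast-clearance side of these three numbers. Compound 1 lies well apart, and the measured step of a 12-fold higher number from compound 1 to compound 2 (1.09 log units; beyond the scatter) is large and beyond the scatter. Compound 4 `CC(C)CN(c1ccc(C#N)cc1)S(=O)(=O)c1ccc2c(c1)C(O)CC(C1CCOCC1)O2` keeps the isobutyl on the sulfonamide nitrogen of compound 2 and alters one group: cyano in place of ethyl on an aromatic carbon is cyano in place of ethyl on an aromatic carbon, or 4-ethylphenyl to 4-cyanophenyl. Going by the values given here, no measured step touches this place. Among the compounds with values here, the one step available is isobutyl in place of cyclobutyl on a sulfonamide nitrogen, so it bears only indirectly, showing that a single change in this set can move the number far. With compound 2 at 330 mL/min/kg and compound 1 at 27.1 mL/min/kg there is wide room downward, and a modest fall is expected, though no measurement fixes its size. The expected change is a 2.2-fold lower number from compound 2 to compound 4 (0.34 log units; beyond the scatter) by this estimate, close to the edge of the scatter. Compound 4 is estimated at 150 mL/min/kg with an expected range from 45 mL/min/kg to 420 mL/min/kg in this assay.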

Compound 4, clearance: 1520 mL/min/kg
Beside the measured number, compound 4's estimate is 10-fold (1.01 log units) below it; measured number above the stated range.
By their numbers in this assay, from the lowest: compound 1; then compounds 3 and 2 (each within the scatter of the next); then compound 4.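

Going by these compounds alone, the swap of ethyl for cyano gives the first measured step at this position in this assay, a 4.6-fold higher number from compound 2 to compound 4 (0.66 log units; beyond the scatter), so a change on the aromatic carbon, para to a large group, can also move the number beyond the scatter, as the change on the sulfonamide nitrogen did with a 12-fold higher number from compound 1 to compound 2 (1.09 log units; beyond the scatter). The direction is towards faster clearance, and it comes from an exchange of two groups of 2 heavy atoms each, in which cyano brings a triple bond and a hydrogen-bond acceptor that ethyl does not have. Nothing given here ties the rise to either of these differences or to any other cause.

From the compounds shown here alone, whether the swap from 4-ethylphenyl to 4-cyanophenyl would raise the number by a similar amount with the cyclobutyl of compound 1 on the sulfonamide nitrogen remains open, since this step has been read only with the isobutyl. Also open, going by these compounds, is how this position would respond to other groups, such as an amine, a carboxylic acid or a longer chain, and so whether the rise is particular to cyano.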